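This account rests on a few compounds, and the source may have more. Where it says the series, first, only, none or still open, it means among the compounds named here.

Of the compounds shown here, two built on one shared core have been tested in a functional assay on B16-F10 cells (Mus musculus) for inhibition, read by MTT assay, with a stated time of 72 h; on this read-out higher numbers stand for weaker inhibition and lower numbers for stronger inhibition. Compound 1 `CC(C)c1ccc(-c2nc(SCc3cn(CC(=O)NC(=O)Nc4ccccn4)nn3)nc(Nc3cccc([N+](=O)[O-])c3)c2C#N)cc1` gives 26400 nM in this assay, and compound 2 `COc1ccccc1Nc1nc(SCc2cn(CC(=O)NC(=O)Nc3ccccn3)nn2)nc(-c2ccc(C(C)C)cc2)c1C#N` gives 34600 nM. For the measured compounds named here, the single step between them, a 1.3-fold higher number from compound 1 to compound 2 (0.12 log units; within the scatter), exchanges 2-methoxyphenyl for 3-nitrophenyl on a nitrogen on an aromatic ring. Going by the values given here, of the two numbers measured, the one for compound 2 is nominally the higher, yet its gap to compound 1 lies within the usual scatter, so the two compounds cannot be separated on these data.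

Compound 3 `CC(C)c1ccc(-c2nc(SCc3cn(CC(=O)NC(=O)Nc4ccccn4)nn3)nc(Nc3ccccc3O)c2C#N)cc1` differs from compound 2 by hydrogen in place of methyl on an oxygen on an aromatic ring. Among the compounds with values here, no measured step removes a methyl from an oxygen; the one measured step swaps the whole aryl group on the nitrogen and so bears only loosely on this change. With nothing pointing one way or the other, the expectation for the step from compound 2 to compound 3 is a 1.2-fold lower number from compound 2 to compound 3 (0.06 log units; within the scatter), no move beyond the scatter. For compound 3 the estimated value in this assay is 30000 nM, with a likely range from 12000 nM to 75000 nM.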

Compound 3, half-maximal inhibitory concentration: 16100 nM
For compound 3 the middle estimate is 1.9-fold (0.27 log units) above the measured one, within the range that was stated.
By their numbers in this assay, from the lowest: compounds 3, 1 and 2 (each within the scatter of the next, the first and the last beyond it).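

In this assay, the change from methoxy to hydroxy on the aromatic ring gives a 2.1-fold lower number from compound 2 to compound 3 (0.33 log units; beyond the scatter), a modest step but the first in this set to pass beyond the scatter. The earlier step swapped the whole aryl group on the nitrogen and could separate nothing, whereas removing only the methyl from this oxygen does separate two compounds. For the compounds shown here, the other new step, a 1.6-fold lower number from compound 1 to compound 3 (0.21 log units; within the scatter), stays within the scatter, so 2-hydroxyphenyl and 3-nitrophenyl on that nitrogen cannot be told apart, and only the pair that differs by the methyl shows a real gap; no other data accompany these numbers that could account for that gap.

On these data alone, what remains open is how the number responds to other groups at this place: an ethyl on the same oxygen, or an amine standing where the hydroxy stands, would show whether the hydrogen itself matters. As far as these compounds go, all three compounds also share the rest of their structure, so whether the same step would appear with another group elsewhere on the shared core is unknown.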